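Fluoro scan on the aryl amine across two cores

This account rests on a few compounds, and the source may have more. Where it says the series, first, only, none or still open, it means among the compounds named here.

Compound 1 `O=C(O)c1cccc(-c2csc(Nc3ccc(F)cc3)n2)c1` and compound 2 `O=C(O)c1cccc(-c2csc(Nc3ccccc3)n2)c1` share one core; compound 3 `O=C(O)c1cccc(-c2cnc(Nc3ccccc3F)o2)c1` carries another, and the difference between the two cores is not broken down here. In a physicochemical assay for solubility, using the shake flask method, measured as kinetic solubility, at pH 7.4 (a higher number here means a more soluble compound, a lower number a less soluble compound), compound 2 gives 70200 nM and compound 1 gives 77700 nM; the change fluoro in place of hydrogen on an aromatic carbon made a 1.1-fold higher number from compound 2 to compound 1 (0.04 log units; within the scatter). In this assay compound 3 gives 55600 nM. Compound 4 `O=C(O)c1cccc(-c2cnc(Nc3ccc(F)cc3F)o2)c1`, not yet measured, differs from compound 3 by fluoro in place of hydrogen on an aromatic carbon. This is the same kind of change as from compound 2 to compound 1, though here the place is also meta to a fluoro group. For compound 4 the expected step in this assay is a 1.0-fold lower number from compound 3 to compound 4 (0.00 log units; within the scatter), beside a 1.1-fold higher number from compound 2 to compound 1 (0.04 log units; within the scatter), resting on that earlier step being within the scatter. Compound 4 is therefore estimated at 55000 nM, between 30000 nM and 100000 nM.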

Compound 4, solubility: 69000 nM
Compound 4: middle estimate off by 1.3-fold (0.10 log units), on the low side; the range from low to high includes it.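

In this assay, fluoro in place of hydrogen on an aromatic carbon gives a 1.2-fold higher number from compound 3 to compound 4 (0.09 log units; within the scatter) on one core and a 1.1-fold higher number from compound 2 to compound 1 (0.04 log units; within the scatter) on the other, so neither step can be told from repeat measurement. On these two pairs the change carries from one core to the other without a readable shift, although in compound 4 the place is also meta to a fluoro group; this does not show that the two cores would respond alike to a change with a larger step. Nothing at hand bears on why the numbers stay so close.

On these data alone, how a trifluoromethyl, methoxy or amine group in place of the added fluoro would read in this assay stays open. So does the reading of either core with an amide in place of the carboxylic acid.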